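A Cyanosulfanyl Group Added to a Weakly Active Core

The source may hold more compounds than are shown below. What is called first, only, known or untested is meant among the compounds shown, and "the series" means these compounds.

Compound 1 `Cc1ccc(-c2cn3nc(Cc4ccc(Cl)cc4)sc3n2)cc1` was tested in a functional assay on L1210 cells (Mus musculus) for cytotoxicity, with a stated time of 48 h; a higher number here means a weaker inhibitor, a lower number a stronger inhibitor. In this assay compound 1 gives > 250000 nM, which is a limit of the assay and not a number. Compound 2 `Clc1ccc(Cc2nn3cc(-c4ccccc4)nc3s2)cc1` gives > 250000 nM in this assay, again a limit. Compound 3 `O=[N+]([O-])c1ccc(-c2cn3nc(Cc4ccc(Cl)cc4)sc3n2)cc1` gives 214000 nM in this assay. The step from compound 1 to compound 2 is a step that the two limits leave unreadable from compound 1 to compound 2, the step from compound 1 to compound 3 is an at least 1.1-fold lower number from compound 1 to compound 3 (0.06 log units; that floor lies within the scatter), and the step from compound 2 to compound 3 is an at least 1.1-fold lower number from compound 2 to compound 3 (0.06 log units; that floor lies within the scatter). Among the measured compounds shown here, compound 1 therefore stands at the limit of > 250000 nM in this assay, at which 2 of the 3 values shown sit, and no measured compound moves clearly away from it.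

Compound 4 `Cc1ccc(-c2nc3sc(Cc4ccc(Cl)cc4)nn3c2SC#N)cc1` differs from compound 1 by cyanosulfanyl in place of hydrogen on an aromatic carbon. For the measured compounds named here, none of the measured steps touches this part of the shared core; they all vary the group on the phenyl ring, so they give no direct guide to the size of this change. The step from compound 1 to compound 4 is therefore expected to be an at least 1.2-fold lower number from compound 1 to compound 4 (0.09 log units; that floor lies within the scatter), with no direction beyond the scatter, and a limit is quite likely again. Compound 4 is estimated at 200000 nM in this assay, within the range from 80000 nM to 400000 nM.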

Compound 4, half-maximal inhibitory concentration: 32000 nM
Compound 4: middle estimate off by 6.3-fold (0.80 log units), on the high side; the whole stated range lies above it.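

Putting cyanosulfanyl in place of hydrogen on this aromatic carbon of the shared core gives, in this assay, an at least 7.8-fold lower number from compound 1 to compound 4 (0.89 log units; beyond the scatter). The earlier steps only varied the group on the phenyl ring, and none of them could be read as lying beyond the scatter, so this position is the first place among the compounds shown where a change clearly registers. The printed size is only a floor, because compound 1 is held by a limit of the assay and not by a number: the limit of > 250000 nM in this assay, at which 2 of the 4 values shown sit.

As far as these compounds go, whether an amine, a carboxylic acid or a longer chain on this same carbon would give a similar step stays open. Also open, from the compounds shown here alone, is whether the step would hold with hydrogen or nitro in place of the methyl on the phenyl ring, as in compound 2 and compound 3.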